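Chloro on the sulfonyl ring, carried to a second core

The source may report more compounds than this note shows. Statements on the series, on what has been measured and on what is new or still open speak of the compounds shown alone.

In a functional assay on SK-MEL-2 cells (Homo sapiens) for cytotoxicity (a lower number here means a stronger inhibitor, a higher number a weaker inhibitor), compound 1 `Cc1ccc(C2CN(S(=O)(=O)c3ccccc3)C(=O)N2)cc1` gives only a limit, > 316000 nM. Compound 2 `Cc1ccc(C2CN(S(=O)(=O)c3ccc(Cl)cc3)C(=O)N2)cc1` gives 123000 nM in this assay. The change between them is chloro in place of hydrogen on an aromatic carbon, and it made an at least 2.5-fold lower number from compound 1 to compound 2 (0.40 log units; beyond the scatter). Compound 3 `Cc1ccc(C2CNC(=O)N2S(=O)(=O)c2ccccc2)cc1` gives 144000 nM in this assay, a value within the scatter of compound 2; how its core differs from that of compound 1 is not broken down here. Compound 4 `Cc1ccc(C2CNC(=O)N2S(=O)(=O)c2ccc(Cl)cc2)cc1` is not yet measured. Its difference from compound 3 is chloro in place of hydrogen on an aromatic carbon, the same change as that from compound 1 to compound 2, at a place described in the same words. Because an at least 2.5-fold lower number from compound 1 to compound 2 (0.40 log units; beyond the scatter), the expectation for the new pair is a 2.6-fold lower number from compound 3 to compound 4 (0.42 log units; beyond the scatter). Compound 4 is therefore estimated at 55000 nM in this assay, between 20000 nM and 150000 nM.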

Compound 4, half-maximal inhibitory concentration: 255000 nM
Compound 4: the middle estimate sits 4.6-fold (0.67 log units) below what was measured; the whole stated range lies below it.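

In this assay, phenyl to 4-chlorophenyl on the second core gave a 1.8-fold higher number from compound 3 to compound 4 (0.25 log units; within the scatter), so the step beyond the scatter seen on the core of compound 1 did not recur here. Set beside that earlier step, the same change did not carry from one core to the other in this pair of cores: the same change on two cores in this assay, an at least 2.5-fold lower number (0.40 log units; beyond the scatter) from compound 1 to compound 2 and a 1.8-fold higher number (0.25 log units; within the scatter) from compound 3 to compound 4, at least 4.5-fold (0.65 log units) apart, beyond the scatter of two such steps This does not show how large the first step truly is or why the cores part, and compound 1 supplies only a limit: the limit of > 316000 nM in this assay, at which 1 of the 4 values shown sits.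

The compounds shown leave open whether fluoro, methoxy or an amine at this place would also differ between the two cores. They also leave open whether a longer chain in place of the methyl group would alter the comparison.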